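A few compounds are considered here, and "the series" means these few. Any claim that something is new, unique, unknown or untested is made for them only; others in the source may bear on it.

Within the data shown here, compound 3 `Nc1c(C(=O)c2ccc(F)cc2)sc2nc(-c3cccs3)ccc12` gives 1.8 ug/mL in a functional assay on WI-38 VA13 cells (Homo sapiens) for cytotoxicity (a higher number here means that more compound is needed for the effect, a lower number that less compound is needed), the highest of the three numbers so far: compound 1 `COc1ccc(C(=O)c2sc3nc(-c4cccs4)ccc3c2N)cc1` gives 0.77 ug/mL and compound 2 `Nc1c(C(=O)c2cccc(Br)c2)sc2nc(-c3cccs3)ccc12` gives 0.5 ug/mL, with a 2.3-fold higher number from compound 1 to compound 3 (0.37 log units; beyond the scatter) and a 3.6-fold higher number from compound 2 to compound 3 (0.56 log units; beyond the scatter). Compound 4 `Nc1c(C(=O)c2ccc(Br)cc2)sc2nc(-c3cccs3)ccc12` differs from compound 3 only by bromo in place of fluoro on an aromatic carbon. Among the measured compounds shown here, no measured step trades fluoro for bromo at that position; the nearest are the substituent changes on the same phenyl ring, a 2.3-fold higher number from compound 1 to compound 3 (0.37 log units; beyond the scatter) and a 3.6-fold higher number from compound 2 to compound 3 (0.56 log units; beyond the scatter), both modest, and a 1.5-fold lower number from compound 1 to compound 2 (0.19 log units; within the scatter), within the scatter. A modest step toward a lower number is therefore expected, a 2.3-fold lower number from compound 3 to compound 4 (0.35 log units; beyond the scatter). Compound 4 is estimated at 0.8 ug/mL, with a range from 0.35 ug/mL to 1.8 ug/mL in this assay.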

Compound 4, half-maximal effective concentration: 2.8 ug/mL
Compound 4: the middle estimate sits 3.5-fold (0.54 log units) below what was measured, and the stated range ends below it.
By their numbers in this assay, from the lowest: compounds 2 and 1 (each within the scatter of the next); then compounds 3 and 4 (each within the scatter of the next).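

In this assay, bromo in place of fluoro para to a large group leaves the number within the scatter (a 1.6-fold higher number from compound 3 to compound 4 (0.19 log units; within the scatter)), so these two halogens are not separated at this position. Where the bromo sits matters more: 4-bromophenyl in place of 3-bromophenyl gives a larger change (a 5.6-fold higher number from compound 2 to compound 4 (0.75 log units; beyond the scatter)), and bromo in place of methoxy also goes beyond the scatter (a 3.6-fold higher number from compound 1 to compound 4 (0.56 log units; beyond the scatter)). Nothing available explains these differences. Open, on these data alone, is how an amine or a carboxylic acid at this position would read, and whether fluoro would track bromo in the 3-bromophenyl arrangement.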